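The source may hold more compounds than are shown below. What is called first, only, known or untested is meant among the compounds shown, and "the series" means these compounds.

Three compounds built on the core of compound 1 `COc1ccc(-c2cccc(NC(=O)C(Cl)Cl)c2)cc1` have been tested so far in a functional assay on KB 3-1 cells (Homo sapiens) for cytotoxicity, read by MTT assay, with a stated time of 68 h; on this read-out higher numbers stand for weaker inhibition and lower numbers for stronger inhibition. Compound 1 gives > 50000 nM, which is a limit and not a number. Going by the values given here, compound 2 `O=C(Nc1cccc(-c2ccc(F)cc2)c1)C(Cl)Cl` gives 26200 nM, the only true number in the set. Compound 3 `O=C(Nc1cccc(-c2ccc(C(F)(F)F)cc2)c1)C(Cl)Cl` gives > 50000 nM, which is again a limit. Compound 3 thus sits at the limit of > 50000 nM in this assay, at which 2 of the 3 values shown sit.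

Compound 4 `O=C(Nc1cccc(-c2ccc(Cl)cc2)c1)C(Cl)Cl` has chloro in place of trifluoromethyl on an aromatic carbon, para to a large group (chloro in place of trifluoromethyl on an aromatic carbon). Among the compounds with values here, two measured steps bear on this change. Replacing methoxy with fluoro gave an at least 1.9-fold lower number from compound 1 to compound 2 (0.28 log units; that floor lies within the scatter), and replacing fluoro with trifluoromethyl gave an at least 1.9-fold higher number from compound 2 to compound 3 (0.28 log units; that floor lies within the scatter). Chloro is a halogen like fluoro, so the expectation leans toward compound 2 at 26200 nM, though neither step has a readable upper size. The expected change in this assay is modest and toward a lower number, estimated as an at least 1.6-fold lower number from compound 3 to compound 4 (0.22 log units; that floor lies within the scatter). For compound 4 the estimated value is 30000 nM, with an expected range of 13000 nM to 50000 nM.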

Compound 4, half-maximal inhibitory concentration: 38200 nM
The estimate for compound 4 lay 1.3-fold (0.10 log units) below the measured number, and the stated range covers the measured number.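

In this assay, this position now carries a second true number, and chloro in place of fluoro gave a 1.5-fold higher number from compound 2 to compound 4 (0.16 log units; within the scatter), so these two halogens are not told apart here. Chloro in place of trifluoromethyl gave an at least 1.3-fold lower number from compound 3 to compound 4 (0.11 log units; that floor lies within the scatter), and chloro in place of methoxy gave an at least 1.3-fold lower number from compound 1 to compound 4 (0.11 log units; that floor lies within the scatter), so neither step is firmly shown to be a real change. Compound 1 and compound 3 each still carry a limit and not a number, so only the fluoro and chloro compounds have a step of readable size: the limit of > 50000 nM in this assay, at which 2 of the 4 values shown sit.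

On these data alone, it remains open whether any group at this position can move the number beyond the scatter. An amine or a carboxylic acid on the same aromatic carbon would test this, as would a longer chain.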